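From 3-chlorophenyl to 4-bromophenyl at the assay limit

The source may hold more compounds than are shown below. What is called first, only, known or untested is meant among the compounds shown, and "the series" means these compounds.

In a functional assay on MCF7 cells (Homo sapiens) for antiproliferative activity, read by MTT assay, with a stated time of 72 h (on this read-out lower numbers stand for stronger inhibition and higher numbers for weaker inhibition), compound 2 (`CCCSc1nc(N/N=C/c2cccc(Cl)c2)c2nnn(Cc3ccccc3)c2n1`) reads > 64000 nM as a limit and not a number. Compound 1 (`CCCSc1nc(N/N=C(\C)c2ccc(O)cc2)c2nnn(Cc3ccccc3)c2n1`) gives 21600 nM and compound 3 (`C#CCSc1nc(N/N=C/c2c(O)ccc3ccccc23)c2nnn(Cc3ccccc3)c2n1`) gives 8970 nM on the same read-out. Compound 2 thus has no exact place among them (the limit of > 64000 nM in this assay, at which 1 of the 3 values shown sits). Compound 4 (`CCCSc1nc(N/N=C/c2ccc(Br)cc2)c2nnn(Cc3ccccc3)c2n1`) differs from compound 2 by one change (4-bromophenyl in place of 3-chlorophenyl on a carbon with a double bond to nitrogen) with 4-bromophenyl in place of 3-chlorophenyl on a carbon with a double bond to nitrogen. For the measured compounds named here, the one measured step that bears on this (an at least 2.9-fold higher number from compound 1 to compound 2 (0.47 log units; beyond the scatter)) was at least modest and ended at that limit. Since both groups are halogen-bearing phenyl rings, the expected step (an at least 1.0-fold lower number from compound 2 to compound 4 (0.02 log units; that floor lies within the scatter)) is none beyond the scatter in this assay for now. For compound 4 the estimate is 60000 nM with an expected range of 20000 nM to 100000 nM in this read-out.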

Compound 4, half-maximal inhibitory concentration: > 64000 nM
Compound 4 ended at the assay's limit; the forecaster's own chance of this, stated with the estimate: 55%; middle value at least 1.0-fold (0.02 log units) from the limit.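

Compound 4 joins compound 2 at the limit of this assay, so a second halogen-bearing phenyl ring gives no measurable number here, and the step between these two limits cannot be read. For the compounds shown here, the one readable step is an at least 2.9-fold higher number from compound 1 to compound 4 (0.47 log units; beyond the scatter). Both compounds therefore share one reading, which is a limit rather than a number: the limit of > 64000 nM in this assay, at which 2 of the 4 values shown sit.

As far as these compounds go, whether 4-bromophenyl and 3-chlorophenyl truly differ stays open. Also open, from the compounds shown here alone, is how a phenyl ring carrying an amine or a carboxylic acid would read at this place.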